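The source may hold more compounds than are shown below. What is called first, only, known or untested is meant among the compounds shown, and "the series" means these compounds.

Working notes on the series. Compound 1 `CCOC(=O)c1cc2ccc(OCCCn3cc(CNC(=O)CCCCC4CCSS4)nn3)cc2oc1=O` gives 28% in a functional assay on PC-12 cells (Rattus norvegicus) for cytotoxicity, read by MTT assay, with stated times of 3 h and 2 h, tested at 0.1 uM; on this read-out higher numbers stand for a stronger effect at the one concentration tested and lower numbers for a weaker effect. Compound 2 `O=C(CCCCC1CCSS1)NCc1cn(CCCOc2ccc3cc(-c4ccccc4)c(=O)oc3c2)nn1` gives 33.9% in this assay; the change phenyl in place of ethoxycarbonyl on an aromatic carbon made a step of a number 5.9 percentage points higher from compound 1 to compound 2 (within the scatter). Compound 3 `CCOC(=O)c1cc2ccc(OCCCCCn3cc(CNC(=O)CCCCC4CCSS4)nn3)cc2oc1=O` gives 34.4% in this assay. The difference between the core of compound 1 and the core of compound 3 is not broken down here. Compound 4 `O=C(CCCCC1CCSS1)NCc1cn(CCCCCOc2ccc3cc(-c4ccccc4)c(=O)oc3c2)nn1` is not yet measured; it differs from compound 3 by phenyl in place of ethoxycarbonyl on an aromatic carbon, the same change as from compound 1 to compound 2, at the same place. The expected step is a number 5.6 percentage points higher from compound 3 to compound 4 (within the scatter), resting on the earlier step of a number 5.9 percentage points higher from compound 1 to compound 2 (within the scatter) and on the value of compound 3 34.4%. Compound 4 is estimated to give 40% in this assay, expected between 28% and 52%.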

Compound 4, a percentage reported as activity, at one concentration (the size of the read-out at that concentration, not a potency): 35.5%
For compound 4 the middle estimate is 4.5 percentage points above the measured one; low and high end bracket the measured number.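

In this assay, phenyl in place of ethoxycarbonyl on an aromatic carbon gives a step of a number 1.1 percentage points higher from compound 3 to compound 4 (within the scatter). Set beside the earlier step, the change shows no difference between the two cores that can be told apart: the same change on two cores in this assay, a number 5.9 percentage points higher (within the scatter) from compound 1 to compound 2 and a number 1.1 percentage points higher (within the scatter) from compound 3 to compound 4, 4.8 percentage points apart, within the scatter of two such steps Both steps lie within the scatter, so the pair shows only that the change has no clear effect on either core; it does not show that a real effect carries from one core to another.

The compounds shown leave open whether a group such as an amine or a carboxylic acid on this aromatic carbon would give a step beyond the scatter. Also open, from the compounds shown here alone, is how the change would behave with a longer chain in the linker.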